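A few compounds are considered here, and "the series" means these few. Any claim that something is new, unique, unknown or untested is made for them only; others in the source may bear on it.

In a functional assay on MCF7 cells (Homo sapiens) for inhibition, read by MTT assay (a lower number here means a stronger inhibitor of growth, a higher number a weaker inhibitor of growth), compound 1 (`COc1cc2oc(-c3cccc(NC(=O)c4ccccc4)c3)cc(=O)c2c(OC)c1OC`) gives 12100 nM and compound 2 (`COc1cc2oc(-c3cccc(NC(=O)c4ccc(Br)cc4)c3)cc(=O)c2c(OC)c1OC`) gives 9650 nM on the same read-out, so compound 2 stands level with compound 1 within the scatter. Compound 3 (`COc1cc2oc(-c3cccc(NC(=O)c4cccc(Br)c4)c3)cc(=O)c2c(OC)c1OC`) carries 3-bromophenyl in place of 4-bromophenyl on a carbonyl carbon with the same atoms joined differently. Going by the values given here, only one measured step bears on this change. Because of a 1.3-fold lower number from compound 1 to compound 2 (0.10 log units; within the scatter) on adding bromo in place of hydrogen on an aromatic carbon, no shift beyond the scatter is expected in this assay here. The expected step is a 1.0-fold higher number from compound 2 to compound 3 (0.02 log units; within the scatter) by this estimate. The estimate for compound 3 is 10000 nM with an expected range from 5000 nM to 20000 nM on this read-out.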

Compound 3, concentration for 50% growth inhibition: 6340 nM
Beside the measured number, compound 3's estimate is 1.6-fold (0.20 log units) above it; measured number inside the range.
By their numbers in this assay, from the lowest: compounds 3, 2 and 1 (each within the scatter of the next).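

In this assay there is a 1.5-fold lower number from compound 2 to compound 3 (0.18 log units; within the scatter) on going from 4-bromophenyl to 3-bromophenyl, and a 1.9-fold lower number from compound 1 to compound 3 (0.28 log units; within the scatter) on putting bromo in place of hydrogen on an aromatic carbon. Among these three compounds, then, neither adding the bromo nor changing where it sits on this ring moves growth inhibition beyond the scatter. No evidence is available to explain these small steps. Still open, from the compounds shown here alone, is whether another group on this ring, such as an amine, a carboxylic acid or a longer chain, would give a step beyond the scatter.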